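Removing a Methoxy Group: Two Parallel Steps in Chalcones

The source may report more compounds than this note shows. Statements on the series, on what has been measured and on what is new or still open speak of the compounds shown alone.

Measured compounds:
compound 1, `COc1cccc(/C=C/C(=O)c2cccc(-c3cccc(F)c3)c2)c1OC`: 9200 nM
compound 2, `COc1ccccc1/C=C/C(=O)c1cccc(-c2cccc(F)c2)c1`: 15400 nM
compound 3, `COc1cc(/C=C/C(=O)c2ccc(N)c(-c3ccc(F)cc3)c2)cc(OC)c1OC`: 4210 nM

All three numbers come from a functional assay on HepG2 cells (Homo sapiens) for cytotoxicity, read by sulforhodamine B assay, with a stated time of 48 h; a lower number here means a stronger inhibitor, a higher number a weaker inhibitor. Compound 1 and compound 2 share one core and differ in a single place: hydrogen in place of methoxy on an aromatic carbon. That change produced a 1.7-fold higher number from compound 1 to compound 2 (0.22 log units; within the scatter), so the two compounds are best read as giving the same result within this assay.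

Compound 3 stands on a different core; how the core of compound 3 differs from the core of compound 1 is not broken down here. Its value is the lowest of the three, and the gaps to compound 1 and to compound 2 both lie beyond the scatter.

Compound 4, `COc1ccc(/C=C/C(=O)c2ccc(N)c(-c3ccc(F)cc3)c2)cc1OC`, has not yet been measured. It differs from compound 3 in one place: hydrogen in place of methoxy on an aromatic carbon. Among the measured compounds shown here, this is the same kind of change as the one from compound 1 to compound 2, but not the same: in compound 3 the carbon that loses the methoxy group is also meta to a methoxy group, which is not so in compound 1.

The expectation for compound 4 rests on the step of a 1.7-fold higher number from compound 1 to compound 2 (0.22 log units; within the scatter), and compound 4 is expected to show a step of about a 1.7-fold higher number from compound 3 to compound 4 (0.22 log units; within the scatter). Compound 4 is therefore estimated at 7000 nM, with a likely range from 3000 nM to 16000 nM.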

Compound 4, half-maximal inhibitory concentration: 3780 nM
The estimate for compound 4 lay 1.9-fold (0.27 log units) above the measured number, and the stated range covers the measured number.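

In this assay, hydrogen in place of methoxy on an aromatic carbon gave a 1.1-fold lower number from compound 3 to compound 4 (0.05 log units; within the scatter), so the two compounds are best read as giving the same result. Set beside the earlier step, the change shows no difference between the two cores: the same change on two cores in this assay, a 1.7-fold higher number (0.22 log units; within the scatter) from compound 1 to compound 2 and a 1.1-fold lower number (0.05 log units; within the scatter) from compound 3 to compound 4, 1.9-fold (0.27 log units) apart, within the scatter of two such steps This shows that, in these two pairs, the exchange of this methoxy group for hydrogen leaves no readable mark on the result, whichever of the two cores carries it, but it does not show that the exchange would be as quiet on a third core, or that the two steps are truly identical, since steps this small could hide a modest real difference, and two pairs cannot establish a rule for the series.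

The compounds shown leave open what a group other than hydrogen would do on the same aromatic carbon, such as a hydroxyl group, an ethoxy group or a chlorine atom. They also leave open whether the result would hold if the remaining methoxy groups on this ring were replaced as well, and whether it would hold outside this assay.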